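A few compounds are considered here, and "the series" means these few. Any claim that something is new, unique, unknown or untested is made for them only; others in the source may bear on it.

Compound 1, `Cc1ccccc1-n1cc(COc2cccc(NC(=O)Nc3ccc(Cl)c(C(F)(F)F)c3)c2)nn1`, is the reference point here. In a functional assay on HepG2 cells (Homo sapiens) for inhibition, read by MTT assay, with a stated time of 72 h (on this read-out lower numbers stand for stronger inhibition and higher numbers for weaker inhibition), compound 1 gives 3440 nM, the highest number among the three compounds measured. Compound 2, `O=C(Nc1cccc(OCc2cn(-c3ccccc3F)nn2)c1)Nc1ccc(Cl)c(C(F)(F)F)c1`, gives 1520 nM in this assay, and compound 3, `O=C(Nc1cccc(OCc2cn(-c3cccc(F)c3)nn2)c1)Nc1ccc(Cl)c(C(F)(F)F)c1`, gives 2120 nM. The step between these two, a 1.4-fold higher number from compound 2 to compound 3 (0.14 log units; within the scatter), lies within the scatter, so their numbers are not told apart. Against compound 1 the picture is mixed: a 2.3-fold lower number from compound 1 to compound 2 (0.35 log units; beyond the scatter) is a modest step beyond the scatter, whereas a 1.6-fold lower number from compound 1 to compound 3 (0.21 log units; within the scatter) stays within it.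

Compound 4, `O=C(Nc1cccc(OCc2cn(-c3cccc(Cl)c3)nn2)c1)Nc1ccc(Cl)c(C(F)(F)F)c1`, is not yet measured. It differs from compound 1 by 3-chlorophenyl in place of 2-methylphenyl on an aromatic nitrogen. Among the measured compounds shown here, the steps that bear on this change are those in which the 2-methylphenyl is altered or replaced: a 1.6-fold lower number from compound 1 to compound 3 (0.21 log units; within the scatter), the closest analogue of the new change since a 3-substituted phenyl enters in both cases, and a 2.3-fold lower number from compound 1 to compound 2 (0.35 log units; beyond the scatter). Both point toward a lower number, one within and one just beyond the scatter. For compound 4 a step of similar size is therefore expected, a 1.7-fold lower number from compound 1 to compound 4 (0.24 log units; within the scatter), that is a modest lowering that may or may not clear the scatter. The number for compound 4 in this assay is estimated at 2000 nM, with a likely range from 1000 nM to 4000 nM.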

Compound 4, half-maximal inhibitory concentration: 2020 nM
Compound 4: middle estimate off by 1.0-fold (0.00 log units), on the low side; the range from low to high includes it.
By their numbers in this assay, from the lowest: compounds 2, 4, 3 and 1 (each within the scatter of the next, the first and the last beyond it).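

Compound 4 adds a second halogen to the series on the aromatic nitrogen, and 3-chlorophenyl and 3-fluorophenyl are not told apart in this assay (a 1.0-fold lower number from compound 3 to compound 4 (0.02 log units; within the scatter)). The 3-chlorophenyl is also not told apart from the 2-fluorophenyl (a 1.3-fold higher number from compound 2 to compound 4 (0.12 log units; within the scatter)) or from the 2-methylphenyl (a 1.7-fold lower number from compound 1 to compound 4 (0.23 log units; within the scatter)), so among the four aryl groups shown at this place, only the step (a 2.3-fold lower number from compound 1 to compound 2 (0.35 log units; beyond the scatter)) lies beyond the scatter. No measurement shown gives a reason for these steps.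

The compounds leave open whether the methyl group or the place it occupies sets compound 1 apart from the others, a question that 3-methylphenyl and 2-chlorophenyl would address on the same core. They also leave open how this place responds to groups of another kind, such as a 3-aminophenyl, a 3-carboxyphenyl or a benzyl group, since every group shown here is a phenyl ring bearing a single methyl, fluoro or chloro substituent.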